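This account rests on a few compounds, and the source may have more. Where it says the series, first, only, none or still open, it means among the compounds named here.

Measured so far in a functional assay on C8166 cells (Homo sapiens) for cytotoxicity, read by MTT assay, with a stated time of 72 h; a higher number here means that more compound is tolerated, a lower number that less compound is tolerated:

- compound 1 `Cc1ccc(S(=O)(=O)N2CC3(C[C@H]2C(=O)N/N=C/c2ccccc2[N+](=O)[O-])SCCS3)cc1`: 65000 nM
- compound 2 `COc1ccc(/C=N/NC(=O)Cn2c(=O)c(C)nc3ccccc32)cc1OC`: > 526000 nM, a limit
- compound 3 `COc1ccc(/C=C/C(=O)N2C[C@@H](NC(=O)c3cccnc3)C[C@H]2C(=O)NO)cc1OC`: > 454000 nM, a limit

Within the data shown here, compound 1 holds the only actual number here, as the other two entries are limits. The compound to be measured next, compound 4 `Cc1ccc(S(=O)(=O)N2CC3(C[C@H]2C(=O)N/N=C/c2ccccc2Br)SCCS3)cc1`, keeps the core of compound 1 and changes one group: bromo in place of nitro on an aromatic carbon, ortho to a large group (bromo in place of nitro on an aromatic carbon). Among the measured compounds shown here, no measured pair of close relatives shows what this swap does in this assay, so no change beyond the usual scatter is expected, in either direction. This expectation rests on compound 1 at 65000 nM. The expected step of a 1.1-fold lower number from compound 1 to compound 4 (0.03 log units; within the scatter) is small. Compound 4 is estimated at 60000 nM, with an expected range of 20000 nM to 180000 nM.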

Compound 4, half-maximal cytotoxic concentration: 177000 nM
The estimate for compound 4 lay 3.0-fold (0.47 log units) below the measured number; low and high end bracket the measured number.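

In this assay, replacing 2-nitrophenyl with 2-bromophenyl on the core of compound 1 gives a 2.7-fold higher number from compound 1 to compound 4 (0.44 log units; beyond the scatter). Among these compounds, this is the first sign that the group at this place can change how much compound the cells tolerate, and here the change is modest. It is still one swap in one series, so it sets no trend. As far as these compounds go, whether an amine or a carboxylic acid at this place would move the number further, or in the opposite direction, stays open. Nothing shown accounts for the rise.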